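Moving a methoxy on the phenoxy arm: compound 4 expected

The source may hold more compounds than are shown below. What is called first, only, known or untested is meant among the compounds shown, and "the series" means these compounds.

Measured so far:
compound 1, `COc1cccc(CNCCCNc2ccnc3cc(Oc4ccccc4)ccc23)c1O`: 14500 nM
compound 2, `COc1cccc(Oc2ccc3c(NCCCNCc4cc(F)ccc4OC)ccnc3c2)c1`: 14500 nM
compound 3, `COc1cccc(Oc2ccc3c(NCCCNCc4cccc(OC)c4O)ccnc3c2)c1`: 14500 nM

In a physicochemical assay for solubility, with a stated time of 18 h, at pH 7.4 (on this read-out lower numbers stand for lower solubility and higher numbers for higher solubility), compound 2 gives 14500 nM. On these numbers compound 2 stands level with compound 1 and compound 3, and the three values lie together within the scatter, so no order among them can be read.

Compound 4, `COc1ccc(F)cc1CNCCCNc1ccnc2cc(Oc3ccccc3OC)ccc12`, has not yet been measured in this assay. It shares all its atoms with compound 2, joined differently: 2-methoxyphenyl in place of 3-methoxyphenyl on an oxygen on an aromatic ring.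

Among the measured compounds shown here, no measured step changes this same position, so the two steps recorded can only serve as a background. The step of no change at the digits printed from compound 1 to compound 3 (within the scatter) and the step of no change at the digits printed from compound 2 to compound 3 (within the scatter) both show that changes on the benzyl arm of the shared core left this assay untouched. The change from compound 2 to compound 4 sits on the other arm, the phenoxy side, and is a rearrangement of the same atoms rather than an addition, so the expectation is a step of no size beyond the scatter, in neither direction: the expected step from compound 2 to compound 4 is no change at the digits printed from compound 2 to compound 4 (within the scatter).

Compound 4 is therefore estimated at 14500 nM in this assay, within a range from 7000 nM to 29000 nM.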

Compound 4, solubility: 14500 nM
The estimate for compound 4 equals the measured number at the digits printed, within the range that was stated.
By their numbers in this assay, from the lowest: compounds 1, 2, 3 and 4 (each within the scatter of the next).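

In this assay, moving the methoxy around the ring on the aromatic ether oxygen gives no change at the digits printed from compound 2 to compound 4 (within the scatter), and this is the first step shown in which that group changes place while its atoms stay the same. Among the compounds shown here, until now the only step on this arm was no change at the digits printed from compound 1 to compound 3 (within the scatter), where a methoxy was added to the ring; taken together, the two steps show that neither adding the methoxy nor exchanging 3-methoxyphenyl for 2-methoxyphenyl moves the read-out beyond the scatter in the compounds concerned, each pair on its own benzyl arm. No supporting measurement is available to explain this result.

The compounds shown leave open whether the same holds when a group other than methoxy stands on this ring, such as an amine or a carboxylic acid, since every group compared here at this place is either hydrogen or methoxy. They also leave open whether a longer chain in place of the methoxy methyl, or an amine in the saturated chain of the shared core, would give a step beyond the scatter in this read-out.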